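Chloro and Nitro Analogues Against Vero Cell Growth

The source may report more compounds than this note shows. Statements on the series, on what has been measured and on what is new or still open speak of the compounds shown alone.

Measured so far:
compound 1, `CC1=CC[C@H](C(C)(C)NC(=S)N/N=C/c2ccccc2Cl)CC1`, 74600 nM
compound 2, `CC1=CC[C@H](C(C)(C)NC(=S)N/N=C/c2cccc(Cl)c2)CC1`, 14800 nM
compound 3, `CC1=CC[C@H](C(C)(C)NC(=S)N/N=C/c2ccccc2[N+](=O)[O-])CC1`, 21600 nM

All three were tested in an ADME assay on Vero cells (Chlorocebus sabaeus) for inhibition, read by sulforhodamine B assay, with a stated time of 48 h; a lower number here means a stronger inhibitor of growth, a higher number a weaker inhibitor of growth. Compound 2 differs from compound 1 in that (3-chlorophenyl in place of 2-chlorophenyl on a carbon with a double bond to nitrogen); the step is a 5.0-fold lower number from compound 1 to compound 2 (0.70 log units; beyond the scatter). Compound 3 differs from compound 1 in that (nitro in place of chloro on an aromatic carbon); the step is a 3.5-fold lower number from compound 1 to compound 3 (0.54 log units; beyond the scatter). Compound 2 and compound 3 lie within the usual scatter of each other, so no order between them is claimed.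

Compound 4, `CC1=CC[C@H](C(C)(C)NC(=S)N/N=C/c2cccc([N+](=O)[O-])c2)CC1`, has not yet been measured. Its difference from compound 2 is nitro in place of chloro on an aromatic carbon: the same kind of change as from compound 1 to compound 3, but here the place is meta to a large group rather than ortho to a large group. The step from compound 2 to compound 4 is expected to be a 1.9-fold lower number from compound 2 to compound 4 (0.27 log units; within the scatter), smaller than the earlier one because a 3.5-fold lower number from compound 1 to compound 3 (0.54 log units; beyond the scatter) stands at a different place. Compound 4 is estimated at 8000 nM, between 2500 nM and 25000 nM.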

Compound 4, concentration for 50% growth inhibition: > 100000 nM
Compound 4 was reported as a limit (the forecaster's own chance of this, stated with the estimate: 5%); middle value at least 12-fold (1.09 log units) from the limit.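

In this assay compound 4 is reported as > 100000 nM, which is a limit of the assay and not a number: the limit of > 100000 nM in this assay, at which 1 of the 4 values shown sits. Nitro in place of chloro gives an at least 6.7-fold higher number from compound 2 to compound 4 (0.82 log units; beyond the scatter), so the change does not carry over from one core to the other, even in direction: the same change on two cores in this assay, a 3.5-fold lower number (0.54 log units; beyond the scatter) from compound 1 to compound 3 and an at least 6.7-fold higher number (0.82 log units; beyond the scatter) from compound 2 to compound 4, at least 23-fold (1.36 log units) apart, beyond the scatter of two such steps This shows that, in this series, the step seen with compound 1 and compound 3 does not foretell the step with compound 2 and compound 4, but with one pair on each core and one end a limit, it shows neither the true size of the new step nor its cause.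

The compounds shown leave open how an amine or a nitrile in place of chloro would behave on either core. They also leave open whether the gap between the two steps would hold for such groups.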